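Compound 4: a larger aromatic group in place of phenoxy

A few compounds are considered here, and "the series" means these few. Any claim that something is new, unique, unknown or untested is made for them only; others in the source may bear on it.

The three measured compounds share one core and differ only in the group on a saturated ring carbon. Compound 1 `O=C1c2ccccc2CCCN1CCN1CCC(Oc2ccccc2)CC1` gives 20.4 nM in an assay on isolated protein for binding affinity to 5-hydroxytryptamine receptor 7 (Homo sapiens) (on this read-out lower numbers stand for stronger inhibition and higher numbers for weaker inhibition), the highest of the three numbers. Compound 2 `O=C1c2ccccc2CCCN1CCN1CCC(Oc2ccc(Cl)cc2)CC1` gives 11.8 nM, and the step of a 1.7-fold lower number from compound 1 to compound 2 (0.24 log units; within the scatter) stays within the scatter. Compound 3 `O=C1c2ccccc2CCCN1CCN1CCC(c2c[nH]c3ccccc23)CC1` gives 0.407 nM; the step of a 50-fold lower number from compound 1 to compound 3 (1.70 log units; beyond the scatter) is large, and a 29-fold lower number from compound 2 to compound 3 (1.46 log units; beyond the scatter) is of the same kind.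

Compound 4 `O=C1c2ccccc2CCCN1CCN1CCC(n2nnc3cc(F)ccc32)CC1` differs from compound 1 as follows: a group of 10 heavy atoms (6 carbon, 3 nitrogen, 1 fluorine; one five-membered aromatic ring with 3 hetero atoms, one six-membered aromatic ring of carbon only) in place of a group of 7 heavy atoms (6 carbon, 1 oxygen; one six-membered aromatic ring of carbon only), on a saturated ring carbon. Within the data shown here, the step that bears on this most is the one from compound 1 to compound 3, where a group holding a five-membered aromatic ring and a six-membered aromatic ring of carbon only entered on the same saturated ring carbon and gave a 50-fold lower number from compound 1 to compound 3 (1.70 log units; beyond the scatter). The entering group of compound 4 likewise holds one five-membered aromatic ring and one six-membered aromatic ring of carbon only, though its five-membered ring has 3 hetero atoms rather than the 1H-indol-3-yl pattern. On that basis a lower number than compound 1 is expected, not necessarily as low as compound 3. The step from compound 1 to compound 4 is expected to be a 6.8-fold lower number from compound 1 to compound 4 (0.83 log units; beyond the scatter). For compound 4 the estimate is 3 nM, with a range from 0.8 nM to 12 nM.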

Compound 4, inhibition constant: 2.04 nM
Estimate against measurement, compound 4: 1.5-fold (0.17 log units) above; the measured number falls inside the stated range.
By their numbers in this assay, from the lowest: compound 3; then compound 4; then compounds 2 and 1 (each within the scatter of the next).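

In this assay, the low number at this saturated ring carbon no longer rests on 1H-indol-3-yl alone: with a different group holding one five-membered aromatic ring and one six-membered aromatic ring of carbon only, the series shows a 10-fold lower number from compound 1 to compound 4 (1.00 log units; beyond the scatter) and a 5.8-fold lower number from compound 2 to compound 4 (0.76 log units; beyond the scatter). Among these four compounds, both groups of this two-ring kind give lower numbers than both phenoxy-type groups, and no compound goes against that, yet the two-ring kind alone does not fix the value, as shown by a 5.0-fold higher number from compound 3 to compound 4 (0.70 log units; beyond the scatter). That last step changes the five-membered ring's hetero atoms and adds fluorine in a single move, so its size cannot be assigned to either feature, and no measurement at hand explains any of these differences.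

As far as these compounds go, what the fluorine contributes on its own remains open, as does the share of the gap that belongs to the ring with 3 hetero atoms. Also open, from the compounds shown here alone, is whether methoxy or an amine in the fluorine's place would keep the number near that of compound 4.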